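From Acetyl to 3,4-Dimethoxyphenyl: What Compound 4 May Show

This account rests on a few compounds, and the source may have more. Where it says the series, first, only, none or still open, it means among the compounds named here.

Measured so far:
compound 1, `COc1ccc(-c2cc3ccc(OCCCn4cc(CNC(=O)CCCCC5CCSS5)nn4)cc3oc2=O)cc1`: 42%
compound 2, `O=C(CCCCC1CCSS1)NCc1cn(CCCCCOc2ccc3ccc(=O)oc3c2)nn1`: 46.3%
compound 3, `CC(=O)c1cc2ccc(OCCCCCn3cc(CNC(=O)CCCCC4CCSS4)nn3)cc2oc1=O`: 28.9%

In a functional assay on PC-12 cells (Rattus norvegicus) for cytotoxicity, read by MTT assay, with stated times of 3 h and 2 h, tested at 0.1 uM (on this read-out higher numbers stand for a stronger effect at the one concentration tested and lower numbers for a weaker effect), compound 3 gives 28.9%, the lowest of the three numbers; compound 1 stands higher at 42% and compound 2 higher still at 46.3%, both beyond the scatter. Compound 4, `COc1ccc(-c2cc3ccc(OCCCCCn4cc(CNC(=O)CCCCC5CCSS5)nn4)cc3oc2=O)cc1OC`, differs from compound 3 in one place: 3,4-dimethoxyphenyl in place of acetyl on an aromatic carbon. Among the compounds with values here, only one measured step bears on this position: a number 17.4 percentage points lower from compound 2 to compound 3 (beyond the scatter), so removing the acetyl is linked to a modest rise. Compound 1 carries a 4-methoxyphenyl at the same place but with a shorter chain, and it gives 42%; it differs from compound 3 in two places, so only its value can be set beside that of compound 3. Taken together, a rise of modest size is expected for compound 4, that is a number 12.1 percentage points higher from compound 3 to compound 4 (beyond the scatter). Compound 4 is therefore estimated at 41%, within a range of 27% to 55%.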

Compound 4, a percentage reported as activity, at one concentration (the size of the read-out at that concentration, not a potency): 38.5%
Compound 4: middle estimate off by 2.5 percentage points, on the high side; low and high end bracket the measured number.
By their numbers in this assay, from the lowest: compounds 3, 4, 1 and 2 (each within the scatter of the next, the first and the last beyond it).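

The carbon two atoms from the ring oxygen also carries 3,4-dimethoxyphenyl, with its aromatic ring, and the outcome cannot be separated from either of the two simpler compounds: a number 9.6 percentage points higher from compound 3 to compound 4 (within the scatter), and a number 7.8 percentage points lower from compound 2 to compound 4 (within the scatter). Within the data shown here, the only earlier step at this place, acetyl in place of hydrogen, lay beyond the scatter, whereas compound 4 lies within the scatter of both its ends, so the data do not rank 3,4-dimethoxyphenyl against hydrogen or acetyl. No measurement shown offers a reason for these numbers.

As far as these compounds go, how an amine or a carboxylic acid on this carbon would read remains open. Also open, from the compounds shown here alone, is whether 3,4-dimethoxyphenyl would give a similar number with a longer chain.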